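Acetylated sugar conjugates of a naphthoquinone: one swap, two cores

The compounds below may be only part of what the source reports. "The series", "measured", "known", "first", "only" and "open" are said of these compounds alone.

Of the compounds shown here, three have been measured in a functional assay on MCF7 cells (Homo sapiens) for cytotoxicity, read by sulforhodamine B assay, with a stated time of 72 h; on this read-out lower numbers stand for stronger inhibition and higher numbers for weaker inhibition. Compound 1 `CC(=O)OC[C@H]1O[C@H](OC2=CC(=O)c3ccccc3C2=O)[C@H](OC(C)=O)[C@@H](OC(C)=O)[C@@H]1OC(C)=O` gives 3520 nM in this assay. Compound 2 `CC(=O)N[C@H]1[C@@H](OC2=CC(=O)c3ccccc3C2=O)O[C@H](COC(C)=O)[C@@H](OC(C)=O)[C@@H]1OC(C)=O` carries acetamido in place of acetoxy on a saturated ring carbon and gives 6590 nM in this assay; the step is a 1.9-fold higher number from compound 1 to compound 2 (0.27 log units; within the scatter). Compound 3 `CC(=O)OC[C@H]1O[C@@H](n2cc(COC3=CC(=O)c4ccccc4C3=O)nn2)[C@H](OC(C)=O)[C@@H](OC(C)=O)[C@@H]1OC(C)=O` gives 3330 nM in this assay, and its numbers against compound 1 and compound 2 both lie within the scatter, so no ordering among the three is claimed. The difference between the core of compound 3 and the core of compound 1 is not broken down here.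

Compound 4 `CC(=O)N[C@@H]1[C@@H](OC(C)=O)[C@H](OC(C)=O)[C@@H](COC(C)=O)O[C@H]1n1cc(COC2=CC(=O)c3ccccc3C2=O)nn1` has not been measured. Against compound 3 it carries acetamido in place of acetoxy on a saturated ring carbon, the same change as that from compound 1 to compound 2. Going by the values given here, because that earlier step was a 1.9-fold higher number from compound 1 to compound 2 (0.27 log units; within the scatter), a step of about the same size is expected here, estimated as a 1.8-fold higher number from compound 3 to compound 4 (0.26 log units; within the scatter), with a wide range since only one prior example exists and it sits on a different core. Compound 4 is therefore expected to give about 6000 nM in this assay, estimated between 3000 nM and 12000 nM.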

Compound 4, half-maximal inhibitory concentration: 28900 nM
Beside the measured number, compound 4's estimate is 4.8-fold (0.68 log units) below it; measured number outside the range, above it.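

In this assay, acetamido in place of acetoxy on a saturated ring carbon gives an 8.7-fold higher number from compound 3 to compound 4 (0.94 log units; beyond the scatter), so on the core of compound 3 this swap is a real loss on this read-out. The change does not carry over at a fixed size from one core to the other: the same change on two cores in this assay, a 1.9-fold higher number (0.27 log units; within the scatter) from compound 1 to compound 2 and an 8.7-fold higher number (0.94 log units; beyond the scatter) from compound 3 to compound 4, 4.6-fold (0.67 log units) apart, beyond the scatter of two such steps. This shows that the step on the core of compound 1 cannot be used to size the step on the core of compound 3, but one pair on each core gives no rule for any further core and does not show what in the cores sets the gap.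

Open, as far as these compounds go, is whether the gap between the cores persists with a free hydroxyl or an amine in place of acetamido at that same saturated ring carbon, on both cores. Also open, from the compounds shown here alone, is whether a longer chain between the sugar and the quinone part of compound 3 and compound 4 widens or narrows the step.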